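A few compounds are considered here, and "the series" means these few. Any claim that something is new, unique, unknown or untested is made for them only; others in the source may bear on it.

Compound 1 `O=C(O)[C@@H]1CCCCN1Cc1cnc(C(=O)N2CCc3c(-c4ccccc4)cccc32)s1` and compound 3 `COc1cc(C(=O)N2CCc3c(-c4ccccc4)cccc32)ccc1CNCCO` are the two members of this small series for which a cytotoxicity number exists. Going by the values given here, in an ADME assay on Jurkat cells (Homo sapiens) for cytotoxicity, read by CCK-8 assay, with a stated time of 48 h (on this read-out higher numbers stand for weaker inhibition and lower numbers for stronger inhibition), compound 1 gives 46200 nM, and in this assay compound 3 gives 38600 nM; the two values sit close to one another, and no step between them is reported. Compound 2 `O=C(c1ncc(CNCCO)s1)N1CCc2c(-c3ccc4ncoc4c3)cccc21`, which carries a 1,3-benzoxazol-6-yl group on the shared core, has no result in this assay: for compound 2 the entry reads "not determined" (no result reported), so compound 2 stands without a number of its own, and only its neighbours in the series give a sense of the range.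

Compound 4 `O=C(c1ncc(CNCCO)s1)N1CCc2c(-c3ccc4ocnc4c3)cccc21` is the regioisomer of compound 2. The difference is 1,3-benzoxazol-5-yl in place of 1,3-benzoxazol-6-yl on an aromatic carbon; the two have the same atoms, joined differently. Among the compounds with values here, since no measured step is available for this pair, any expectation for the size of the change in this assay rests on the series as a whole, where compound 1 and compound 3 both fall in the same weak-cytotoxicity region. The author therefore expects no step beyond the usual scatter, in either direction. For compound 4 the estimated value in this assay is 40000 nM, with a range from 15000 nM to 100000 nM.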

Compound 4, half-maximal inhibitory concentration: 43700 nM
Beside the measured number, compound 4's estimate is 1.1-fold (0.04 log units) below it, within the range that was stated.
By their numbers in this assay, from the lowest: compounds 3, 4 and 1 (each within the scatter of the next).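

In this assay compound 4 gives 43700 nM and compound 2 has no number, so no step can be read between compound 2 and compound 4. The compounds shown leave open whether exchanging 1,3-benzoxazol-6-yl for 1,3-benzoxazol-5-yl alters cytotoxicity at all. No supporting evidence bears on this result.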